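Adding a Second Chloro to the Shared Core

The source may hold more compounds than are shown below. What is called first, only, known or untested is meant among the compounds shown, and "the series" means these compounds.

Compound 1 `ClCc1cccc(Cn2cnc3ncnc(Cl)c32)c1` was tested in a functional assay on SK-MEL-2 cells (Homo sapiens) for cytotoxicity, read by sulforhodamine B assay, with a stated time of 48 h (a lower number here means a stronger inhibitor of growth, a higher number a weaker inhibitor of growth), and gave 5750 nM. That is the lower of the two numbers recorded so far. The other measured compound, compound 2 `ClCc1ccc(Cn2cnc3c(Cl)nc(Cl)nc32)cc1`, gave 20000 nM in this assay, a clearly weaker result that lies beyond the usual scatter. Compound 2 differs from compound 1 in more than one place, so the two values show only that one is weaker than the other, not which part of the structure accounts for it.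

Compound 3 `ClCc1cccc(Cn2cnc3nc(Cl)nc(Cl)c32)c1` has not yet been measured. It differs from compound 1 in a single place: chloro in place of hydrogen on an aromatic carbon. The new chloro sits between two ring nitrogen atoms of the shared core. Among the compounds with values here, no single-change step between measured compounds exists to guide this, so the expected shift from compound 1 to compound 3 is taken as small and slightly toward weaker growth inhibition, estimated at a 1.5-fold higher number from compound 1 to compound 3 (0.17 log units; within the scatter). On that basis compound 3 is expected to give about 8500 nM in this assay, most likely between 3000 nM and 25000 nM.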

Compound 3, concentration for 50% growth inhibition: 1770 nM
Compound 3: middle estimate off by 4.8-fold (0.68 log units), on the high side; the measured number lies below the stated range.
By their numbers in this assay, from the lowest: compound 3; then compound 1; then compound 2.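

Placing a chloro on the aromatic carbon between two ring nitrogen atoms of the shared core is the first single change that can be read in this assay, and it gives a 3.2-fold lower number from compound 1 to compound 3 (0.51 log units; beyond the scatter). This shows that the position accepts a chloro in place of a hydrogen atom, and that growth inhibition becomes stronger rather than being lost, by a modest step that lies beyond the usual scatter. Nothing available explains why this change has this effect.

The compounds shown leave open whether this gain is particular to chloro or would also appear with another group at the same position, such as an amine, a methoxy group or a fluoro. They also leave open whether a chloro here would give a step of similar size if the rest of the molecule were different, for example if the chloromethyl group were replaced by a methyl group or a longer chain.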